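Hydroxycarbamoyl to Carbamoyl on a Shared Core

This account rests on a few compounds, and the source may have more. Where it says the series, first, only, none or still open, it means among the compounds named here.

For the measured compounds named here, compound 1 `CC(C)=CCCC1=CC[C@H](C(=O)NO)[C@@H](c2ccccc2)C1` is the only member of this small set for which an assay on isolated protein for inhibition of Apoptosis regulator Bcl-2 (Homo sapiens), read by fluorescence polarization, with stated times of 5 min and 10 min (on this read-out lower numbers stand for stronger inhibition and higher numbers for weaker inhibition), returns a number: compound 1 reaches 600 nM. The two companions rest at a limit of the assay rather than at a number. For compound 2 `CON(C)C(=O)[C@H]1CC2=C(CCCC2(C)C)C[C@@H]1c1ccccc1` the read-out in this assay is the limit > 23000 nM. For compound 3 `CON(C)C(=O)[C@@H]1CC=C(CCC=C(C)C)C[C@H]1c1ccccc1` the read-out in this assay is likewise the limit > 23000 nM. Going by the values given here, both therefore sit at the limit of > 23000 nM in this assay, at which 2 of the 3 values shown sit, and no step between measured compounds is recorded, so their values say only that they stay beyond the reach of the assay while compound 1 is measured.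

The step followed here leads from compound 1 to compound 4 `CC(C)=CCCC1=CC[C@H](C(N)=O)[C@@H](c2ccccc2)C1`, not yet measured in this assay. The change is hydrogen in place of hydroxy on an amide-type nitrogen. Cut one bond further out it reads hydroxycarbamoyl to carbamoyl. Among the compounds with values here, no measured pair in this set shows the same change, so no recorded step fixes its size. Compound 4 is expected to be the weaker binder. The expected step is a 10-fold higher number from compound 1 to compound 4 (1.00 log units; beyond the scatter), beyond the usual scatter. The estimate for compound 4 in this assay is 6000 nM, ranging from 1500 nM to 23000 nM, with a real chance that only a limit is returned.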

Compound 4, inhibition constant: > 23000 nM
Compound 4 ended at the assay's limit; the forecaster's own chance of this, stated with the estimate: 35%; middle value at least 3.8-fold (0.58 log units) away from the limit.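

The change of hydroxy to hydrogen on the amide-type nitrogen gives this set its first readable step, and in this assay it is an at least 38-fold higher number from compound 1 to compound 4 (1.58 log units; beyond the scatter). As the two compounds differ in this one place alone, the measurable value of compound 1 in this set is tied to the hydroxy on that nitrogen, and the loss of this single oxygen atom is enough to leave no number at all. Compound 4 therefore joins compound 2 and compound 3 at a limit of the assay rather than at a number: the limit of > 23000 nM in this assay, at which 3 of the 4 values shown sit.

The full size of the step stays unknown, since the value of compound 4 is only a limit, and the compounds shown cannot tell whether the hydroxy alone matters or the hydroxycarbamoyl as a whole. On these data alone, whether a carboxylic acid in place of the hydroxycarbamoyl, or an amino group in place of the hydroxy on that same nitrogen, would return a number in this assay remains open.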